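The compounds below may be only part of what the source reports. "The series", "measured", "known", "first", "only" and "open" are said of these compounds alone.

In a functional assay on U-87MG ATCC cells (Homo sapiens) for inhibition, read by MTT assay, with a stated time of 72 h (a lower number here means a stronger inhibitor, a higher number a weaker inhibitor), compound 2 `COc1cc2c(Oc3ccc(NC(=O)c4nn(-c5ccccc5)c(=O)cc4C)cc3F)ccnc2cc1OCCCN1CCCCC1` gives 1370 nM. Among the measured compounds shown here, compound 1 `COc1cc2c(Oc3ccc(NC(=O)c4nn(-c5ccccc5)c(=O)cc4C)cc3F)ccnc2cc1OCCCN1CCCC1` gives 1100 nM in this assay, and the only measured step, a 1.2-fold higher number from compound 1 to compound 2 (0.10 log units; within the scatter), leaves the two compounds level within the scatter. Compound 3 `COc1ccc(-n2nc(C(=O)Nc3ccc(Oc4ccnc5cc(OCCCN6CCCCC6)c(OC)cc45)c(F)c3)c(C)cc2=O)cc1` differs from compound 2 by methoxy in place of hydrogen on an aromatic carbon. That measured step concerns the saturated chain, not this aromatic ring, so nothing measured bears directly on the change. The expected step of a 1.1-fold lower number from compound 2 to compound 3 (0.02 log units; within the scatter) is therefore small, with no shift beyond the scatter. Compound 3 is expected to give 1300 nM, estimated between 550 nM and 3200 nM.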

Compound 3, half-maximal inhibitory concentration: 1800 nM
For compound 3 the middle estimate is 1.4-fold (0.14 log units) below the measured one; the range from low to high includes it.
By their numbers in this assay, from the lowest: compounds 1, 2 and 3 (each within the scatter of the next).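

In this assay, methoxy on the aromatic carbon para to a large group gives a 1.3-fold higher number from compound 2 to compound 3 (0.12 log units; within the scatter), so the change from phenyl to 4-methoxyphenyl leaves the two compounds level. Among the compounds shown here, only this step speaks to that ring, as the earlier step concerned the saturated chain. Neither of these two places has yet moved the number beyond the scatter.

As far as these compounds go, whether a different group on this carbon, such as an amine or a carboxylic acid, would shift the number remains open. Nothing available explains this result.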